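Swapping trifluoromethyl for methoxy on compound 3

The source may report more compounds than this note shows. Statements on the series, on what has been measured and on what is new or still open speak of the compounds shown alone.

Going by the values given here, compound 3 `O=C(Nc1ccc(C(F)(F)F)nc1)c1csc(Cc2c(Cl)cccc2Cl)n1` gives 130 nM in an assay on CHO cells, read by calcium flux (on this read-out lower numbers stand for stronger inhibition and higher numbers for weaker inhibition), the lowest of the two numbers known so far. Compound 2 `O=C(Nc1ccc(Br)cc1)c1csc(Cc2c(Cl)cccc2Cl)n1` gives 460 nM in this assay. Compound 1 `COc1ccc(NC(=O)c2csc(Cc3c(Cl)cccc3Cl)n2)cc1` reaches only a limit of the assay, > 4000 nM, in this assay. Compound 4 `COc1ccc(NC(=O)c2csc(Cc3c(Cl)cccc3Cl)n2)cn1` differs from compound 3 by methoxy in place of trifluoromethyl on an aromatic carbon. Among the compounds with values here, the one measured step that involves a methoxy group is an at least 8.6-fold lower number from compound 1 to compound 2 (0.93 log units; beyond the scatter), where methoxy was taken away; here it comes in, and the methoxy-bearing compound 1 sits at the limit of > 4000 nM in this assay, at which 1 of the 3 values shown sits. A weakening step beyond the scatter is therefore expected, a 12-fold higher number from compound 3 to compound 4 (1.06 log units; beyond the scatter). Compound 4 is expected to give 1500 nM in this assay, between 400 nM and 6000 nM, with a fair chance that only a limit is recorded.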

Compound 4, half-maximal inhibitory concentration: > 4000 nM
Compound 4 was reported as a limit (the forecaster's own chance of this, stated with the estimate: 25%); middle value at least 2.6-fold (0.42 log units) away from the limit.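

The large step of an at least 30-fold higher number from compound 3 to compound 4 (1.48 log units; beyond the scatter) shows that this position, next to the ring nitrogen, does not tolerate every small group: methoxy loses what trifluoromethyl gave. Methoxy on this ring also falls short of the bromo compound, with an at least 8.6-fold higher number from compound 2 to compound 4 (0.93 log units; beyond the scatter). The step between compound 1 and compound 4 cannot be read, so any effect of the ring nitrogen on methoxy stays hidden behind the shared limit: the limit of > 4000 nM in this assay, at which 2 of the 4 values shown sit.

Still open, on these data alone, is whether an amine or a simple methyl at this position would hold the number of compound 3. Also open, as far as these compounds go, is how trifluoromethyl behaves on the ring without that nitrogen.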